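Bicyclic amine ether in place of dimethylaminocyclohexyl ether

The compounds below may be only part of what the source reports. "The series", "measured", "known", "first", "only" and "open" are said of these compounds alone.

In an assay on HEK293 cells for displacement of a labelled ligand from melanin-concentrating hormone receptor 1 (Homo sapiens) (on this read-out lower numbers stand for stronger inhibition and higher numbers for weaker inhibition), compound 3 `COc1cc(NC(=O)c2ccc(C3CCCCC3)cc2)ccc1O[C@H]1CCCC[C@@H]1N(C)C` gives 2510 nM, the highest number of the three. Compound 1 `COc1cc(NC(=O)c2ccc(C3CCCCC3)cc2)ccc1OC[C@H]1CCCN1C` gives 79.4 nM and compound 2 `COc1cc(NC(=O)c2ccc(C3CCCCC3)cc2)ccc1OC[C@@H]1CCCN1C` gives 39.8 nM. The steps into compound 3 are a 32-fold higher number from compound 1 to compound 3 (1.50 log units; beyond the scatter) and a 63-fold higher number from compound 2 to compound 3 (1.80 log units; beyond the scatter). Compound 4 `COc1cc(NC(=O)c2ccc(C3CCCCC3)cc2)ccc1OC12CCCN(CC1)C2` carries a group of 8 heavy atoms (7 carbon, 1 nitrogen; one five-membered non-aromatic ring with 1 hetero atom, one six-membered non-aromatic ring with 1 hetero atom) in place of a group of 9 heavy atoms (8 carbon, 1 nitrogen; one six-membered non-aromatic ring of carbon only), on an oxygen on an aromatic ring. Going by the values given here, no measured step covers this exact change, but the two steps into compound 3 show that exchanging the amine-bearing ether group moves this assay by a large amount, and compound 4 again exchanges that group. For compound 4 a step back in the other direction is therefore expected, an 8.4-fold lower number from compound 3 to compound 4 (0.92 log units; beyond the scatter), its size uncertain because the entering group has not been measured in any compound here. Compound 4 is estimated at 300 nM, within 60 nM to 1500 nM.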

Compound 4, inhibition constant: 50.1 nM
Compound 4: the middle estimate sits 6.0-fold (0.78 log units) above what was measured; the measured number lies below the stated range.
By their numbers in this assay, from the lowest: compounds 2, 4 and 1 (each within the scatter of the next); then compound 3.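

In this assay, the large loss seen with 2-(dimethylamino)cyclohexyl does not extend to every amine-bearing ether group on this oxygen: a 50-fold lower number from compound 3 to compound 4 (1.70 log units; beyond the scatter). The bicyclic amine group of compound 4 instead reads within the scatter of both (1-methylpyrrolidin-2-yl)methyl ethers, with a 1.3-fold higher number from compound 2 to compound 4 (0.10 log units; within the scatter) and a 1.6-fold lower number from compound 1 to compound 4 (0.20 log units; within the scatter). Among the four compounds, three amine groups of differing ring shape therefore give similar numbers, and compound 3 is the one that goes against this.

As far as these compounds go, how a plain cyclohexyl group without nitrogen would read on this oxygen stays open. Nothing shown here gives a cause for the gap between compound 3 and the other three compounds.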